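This account rests on a few compounds, and the source may have more. Where it says the series, first, only, none or still open, it means among the compounds named here.

Measured compounds:
compound 1 `Cc1cn(-c2cc(NC(=O)c3ccc(C)c(Nc4nccc(-c5ccccc5)n4)c3)cc(N3CCNCC3)c2)cn1` — 1.64 h
compound 2 `Cc1cn(-c2cc(NC(=O)c3ccc(C)c(Nc4nccc(-c5ccccc5)n4)c3)cc(N3CCN(C)CC3)c2)cn1` — 2.21 h

Both were read in an ADME assay on the whole organism (Mus musculus, strain CD1) for metabolic stability, read by LC-MS, using cassette dosing, with a stated time of 24 h, at a dose of 0.4 mg/kg by the intravenous route; a higher number here means that the compound lasts longer, a lower number that the compound disappears faster. Going by the values given here, compound 1 and compound 2 share one core and differ only by a methyl in place of hydrogen on an amine nitrogen in a ring; the single measured step, a 1.3-fold higher number from compound 1 to compound 2 (0.13 log units; within the scatter), does not separate them beyond the scatter, so compound 2 stands level with compound 1 in this assay rather than apart from it.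

Compound 3 `Cc1cn(-c2cc(CN3CCN(C)CC3)cc(NC(=O)c3ccc(C)c(Nc4nccc(-c5ccccc5)n4)c3)c2)cn1` keeps the ring-bound methyl of compound 2 and changes the attachment instead: (4-methylpiperazin-1-yl)methyl in place of 4-methylpiperazin-1-yl on an aromatic carbon. Among the compounds with values here, no measured step bears on this change; the only step at hand, from compound 1 to compound 2, touches the methyl on the amine nitrogen and not the link to the aromatic carbon, and it was itself within the scatter. The expectation for compound 3 therefore rests on compound 2 alone, and the step is expected to be small, a 1.1-fold lower number from compound 2 to compound 3 (0.04 log units; within the scatter), in no settled direction. Compound 3 is estimated at 2 h in this assay, within a range of 1 h to 4.5 h.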

Compound 3, half-life: 3.29 h
For compound 3 the middle estimate is 1.6-fold (0.22 log units) below the measured one, and the stated range covers the measured number.
By their numbers in this assay, from the lowest: compounds 1, 2 and 3 (each within the scatter of the next).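

In this assay, placing (4-methylpiperazin-1-yl)methyl in place of 4-methylpiperazin-1-yl on an aromatic carbon, meta to a 4-methyl-1H-imidazol-1-yl group, gives a 1.5-fold higher number from compound 2 to compound 3 (0.17 log units; within the scatter) and thus shows that this position accepts the longer attachment without a separation beyond the scatter. The change from piperazin-1-yl to (4-methylpiperazin-1-yl)methyl, which also brings in the methyl on the ring nitrogen, gives a 2.0-fold higher number from compound 1 to compound 3 (0.30 log units; within the scatter) and so also stays inside the scatter, leaving all three compounds level in this measure of how long they last in the mouse. No measurement at hand offers an explanation for these small steps.

The compounds shown leave open whether a group of another kind at this aromatic carbon, such as morpholin-4-yl, a carboxylic acid or a longer chain carrying the 4-methylpiperazin-1-yl ring, would move the half-life beyond the scatter. They also leave open whether an acetyl group in place of the methyl on the ring nitrogen would keep the half-life level with those of these three compounds.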